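The source may report more compounds than this note shows. Statements on the series, on what has been measured and on what is new or still open speak of the compounds shown alone.

Values in a functional assay on MCF7 cells (Homo sapiens) for cytotoxicity, read by MTT assay, with a stated time of 3 days; on this read-out lower numbers stand for stronger inhibition and higher numbers for weaker inhibition:
- compound 1 `C[C@H]1O[C@@H](n2cc(F)c(NC(=O)Oc3ccc([N+](=O)[O-])cc3)nc2=O)[C@@H]2OC(=O)O[C@@H]21`: 6 ug/mL
- compound 2 `C[C@H]1O[C@@H](n2cc(F)c(NC(=O)Oc3ccc([N+](=O)[O-])cc3)nc2=O)[C@H](O)[C@@H]1O`: 180 ug/mL
- compound 3 `CC(C)CCOC(=O)Nc1nc(=O)n([C@@H]2O[C@H](C)[C@H]3OC(=O)O[C@H]32)cc1F`: 100 ug/mL

Compound 2 at 180 ug/mL and compound 3 at 100 ug/mL lie within the scatter of each other, and both stand well clear of compound 1, as a 30-fold higher number from compound 1 to compound 2 (1.48 log units; beyond the scatter) shows for compound 2.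

Not yet measured is compound 4 `CC(C)CCOC(=O)Nc1nc(=O)n([C@@H]2O[C@H](C)[C@@H](O)[C@H]2O)cc1F`, which differs from compound 2 by a single change: isopentyl in place of 4-nitrophenyl on an oxygen next to a carbonyl group. The same exchange of isopentyl for 4-nitrophenyl has been measured once, on the core of compound 1, where a 17-fold higher number from compound 1 to compound 3 (1.22 log units; beyond the scatter) is a large step towards a higher number. The other measured step, a 30-fold higher number from compound 1 to compound 2 (1.48 log units; beyond the scatter), is also large and in the same direction, and compound 2 already carries that change. Whether the two steps add is not shown by any measured pair, and the single exchange comes from a different starting point. A step in the same direction is therefore expected, but much smaller than the full step from compound 1 to compound 3.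

In this assay the estimate is a 2.2-fold higher number from compound 2 to compound 4 (0.35 log units; beyond the scatter). For compound 4 the expected value is 400 ug/mL, with an estimated range of 120 ug/mL to 1500 ug/mL.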

Compound 4, half-maximal inhibitory concentration: 120 ug/mL
For compound 4 the middle estimate is 3.3-fold (0.52 log units) above the measured one; low and high end bracket the measured number.
By their numbers in this assay, from the lowest: compound 1; then compounds 3, 4 and 2 (each within the scatter of the next).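

In this assay, isopentyl in place of 4-nitrophenyl on an oxygen next to a carbonyl group gives a 1.5-fold lower number from compound 2 to compound 4 (0.18 log units; within the scatter), so on the core of compound 2 this exchange produces no readable step. The same exchange therefore cannot be treated as having one size across this series, and its outcome depends on the core that carries it: the same change on two cores in this assay, a 17-fold higher number (1.22 log units; beyond the scatter) from compound 1 to compound 3 and a 1.5-fold lower number (0.18 log units; within the scatter) from compound 2 to compound 4, 25-fold (1.40 log units) apart, beyond the scatter of two such steps. Only compound 1, at 6 ug/mL, combines 4-nitrophenyl with its own core, while compound 3, compound 4 and compound 2 lie each within the scatter of the next, so the low number belongs to that combination rather than to either part alone.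

The compounds shown do not tell whether a plain phenyl, a longer chain or a chain ending in an amine or a carboxylic acid on this oxygen would keep the number of compound 1 on its core or fall in with the other three. They also leave open whether any of these groups would give a readable step on the core of compound 2, where the two groups compared so far do not.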